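This account rests on a few compounds, and the source may have more. Where it says the series, first, only, none or still open, it means among the compounds named here.

Compound 2, `COc1cc(OC)c(/C=C/S(=O)(=O)Cc2ccc(Cl)c(N)c2)c(OC)c1`, is the reference point of this small set: in a functional assay on DU-145 cells (Homo sapiens) for cytotoxicity, read by trypan blue exclusion, with a stated time of 96 h (a higher number here means a weaker inhibitor, a lower number a stronger inhibitor), compound 2 gives 10 nM. Compound 1, `COc1cc(OC)c(/C=C/S(=O)(=O)Cc2ccc(Br)c(N)c2)c(OC)c1`, differs from it by bromo in place of chloro on an aromatic carbon and gives 750 nM in this assay, so that a 75-fold higher number from compound 2 to compound 1 (1.88 log units; beyond the scatter).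

Compound 3, `COC(=O)C(Nc1cc(CS(=O)(=O)/C=C/c2c(OC)cc(OC)cc2OC)ccc1OC)c1ccc(Cl)cc1`, carries a different core; how the two cores differ is not broken down here. In this assay compound 3 gives 400 nM, a value that lies within the scatter of compound 1 and well apart from compound 2.

Compound 4, `COC(=O)C(Nc1cc(CS(=O)(=O)/C=C/c2c(OC)cc(OC)cc2OC)ccc1OC)c1ccc(Br)cc1`, is not yet measured. It differs from compound 3 by bromo in place of chloro on an aromatic carbon. This is the same kind of change as that from compound 2 to compound 1, but the surroundings differ: in the earlier pair the carbon is also ortho to an amino group, whereas here it is only para to a large group. Since the earlier change produced a large weakening, compound 4 is expected to be weaker than compound 3, though with a single example on a different core a more modest step is anticipated: a 3.0-fold higher number from compound 3 to compound 4 (0.48 log units; beyond the scatter). Compound 4 is therefore estimated at 1200 nM, with a plausible range from 300 nM to 6000 nM.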

Compound 4, half-maximal inhibitory concentration: 300 nM
For compound 4 the middle estimate is 4.0-fold (0.60 log units) above the measured one; the measured number falls inside the stated range.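

On the core of compound 3, bromo in place of chloro on an aromatic carbon, here 4-chlorophenyl to 4-bromophenyl, moves the number in this assay only within the scatter (a 1.3-fold lower number from compound 3 to compound 4 (0.12 log units; within the scatter)). The large step seen on the core of compound 2 therefore does not carry over to this core, and the two steps clearly differ: the same change on two cores in this assay, a 75-fold higher number (1.88 log units; beyond the scatter) from compound 2 to compound 1 and a 1.3-fold lower number (0.12 log units; within the scatter) from compound 3 to compound 4, 100-fold (2.00 log units) apart, beyond the scatter of two such steps. This shows that the size of this change depends on the core in these two pairs, but it does not show which of the differences between the two cores lies behind that, and two pairs give no rule for a third core.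

The compounds shown leave open how the core of compound 3 responds to fluoro, iodo, methyl or a nitrile in the same place. They also leave open whether bromo and chloro would still match if the methyl ester of compound 3 and compound 4 gave way to a carboxylic acid.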